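The source may report more compounds than this note shows. Statements on the series, on what has been measured and on what is new or still open speak of the compounds shown alone.

Compound 1 `CCNc1cc(-c2ccc(NC(=O)Nc3c(C)cccc3C)cc2C)ccn1` serves as the reference of the series. In a functional assay on MCF7 cells (Homo sapiens) for cytotoxicity, read by MTT assay, with a stated time of 24 h (on this read-out higher numbers stand for weaker inhibition and lower numbers for stronger inhibition), compound 1 gives 7920 nM. Compound 2 `CCNc1cc(-c2ccc(NC(=O)Nc3ccccc3Cl)cc2C)ccn1` carries the change 2-chlorophenyl in place of 2,6-dimethylphenyl on an amide-type nitrogen and in this assay compound 2 gives 8350 nM; the step of a 1.1-fold higher number from compound 1 to compound 2 (0.02 log units; within the scatter) is small. Compound 3 `CCNc1cc(-c2ccc(NC(=O)Nc3c(C)cccc3C)cc2C(F)(F)F)ccn1` differs from compound 1 by trifluoromethyl in place of methyl on an aromatic carbon, and in this assay compound 3 gives 6950 nM, the step being a 1.1-fold lower number from compound 1 to compound 3 (0.06 log units; within the scatter). All three numbers lie close together.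

Compound 4 `CCNc1cc(-c2ccc(NC(=O)Nc3ccccc3Cl)cc2C(F)(F)F)ccn1` is not yet measured. It stands to compound 3 as compound 2 stands to compound 1: the change 2-chlorophenyl in place of 2,6-dimethylphenyl on an amide-type nitrogen is the same change already made once between compound 1 and compound 2, here on the core of compound 3 rather than the core of compound 1.

Because the earlier step of a 1.1-fold higher number from compound 1 to compound 2 (0.02 log units; within the scatter) was within the scatter, the same step is expected from compound 3 to compound 4, namely a 1.1-fold higher number from compound 3 to compound 4 (0.02 log units; within the scatter). Compound 4 is therefore estimated to give 7300 nM in this assay, with the expected range running from 4500 nM to 12000 nM.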

Compound 4, half-maximal inhibitory concentration: 3680 nM
Compound 4: middle estimate off by 2.0-fold (0.30 log units), on the high side; measured number below the stated range.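

In this assay, 2-chlorophenyl in place of 2,6-dimethylphenyl gives a 1.9-fold lower number from compound 3 to compound 4 (0.28 log units; within the scatter), and this reading does not separate from the earlier one for the same change: the same change on two cores in this assay, a 1.1-fold higher number (0.02 log units; within the scatter) from compound 1 to compound 2 and a 1.9-fold lower number (0.28 log units; within the scatter) from compound 3 to compound 4, 2.0-fold (0.30 log units) apart, within the scatter of two such steps. Trifluoromethyl in place of methyl gives a 2.3-fold lower number from compound 2 to compound 4 (0.36 log units; beyond the scatter), a modest step beyond the scatter, yet its gap to the earlier reading also stays within what two such steps can show: the same change on two cores in this assay, a 1.1-fold lower number (0.06 log units; within the scatter) from compound 1 to compound 3 and a 2.3-fold lower number (0.36 log units; beyond the scatter) from compound 2 to compound 4, 2.0-fold (0.30 log units) apart, within the scatter of two such steps. For the compounds shown here, the four compounds are thus compatible with both changes carrying from one core to another, but they neither show that the two changes depend on each other nor establish that they add independently, as each change is read on only two cores in a single assay.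

Still open, as far as these compounds go, is how the series reads with other groups on the amide-type nitrogen, such as a phenyl ring carrying a nitrile or an amine, or with a methoxy group in place of trifluoromethyl. Also open, from the compounds shown here alone, is whether the step to compound 4 holds up on repeat measurement.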